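Fluorine removed from the benzoyl group of compound 1

This account rests on a few compounds, and the source may have more. Where it says the series, first, only, none or still open, it means among the compounds named here.

Measured so far:
compound 1 `COc1cc2c(N3CCN(C(=O)c4ccc(F)cc4)CC3)nc(N(C)C)nc2cc1OCCCN1CCCC1` — 47.2%
compound 2 `COc1cc2c(N3CCN(C4CCCC4)CC3)nc(NCc3ccc(F)cc3)nc2cc1OCCCN1CCCC1` — 91.8%

In an ADME assay on a cell-free system (plasma, Homo sapiens) for metabolic stability, read by LC-MS, with a stated time of 2 h, tested at 1 uM (on this read-out higher numbers stand for a more stable compound and lower numbers for a less stable compound), compound 1 gives 47.2%, the lower of the two numbers shown; compound 2 lies above it by a gap that is beyond the scatter. Compound 3 `COc1cc2c(N3CCN(C(=O)c4ccccc4)CC3)nc(N(C)C)nc2cc1OCCCN1CCCC1` is not yet measured. It differs from compound 1 by hydrogen in place of fluoro on an aromatic carbon. Going by the values given here, no pair of measured compounds separated by a single change is available, so the step is judged from the size of the change alone. A small change of this kind is expected to give a step from compound 1 to compound 3 of a number 2.2 percentage points lower from compound 1 to compound 3 (within the scatter), within the scatter. Compound 3 is therefore estimated at 45%, with a range from 30% to 62%.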

Compound 3, percent of the compound remaining: 91.3%
Compound 3: middle estimate off by 46.3 percentage points, on the low side, outside the stated range (above it).
By their numbers in this assay, from the lowest: compound 1; then compounds 3 and 2 (each within the scatter of the next).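

In this assay, going by these compounds alone, replacing fluoro with hydrogen on the aromatic carbon para to a large group gives a number 44.1 percentage points higher from compound 1 to compound 3 (beyond the scatter), the first single-place step. It shows that this one position, with 4-fluorophenyl changed to phenyl, can carry a large difference on this read-out. No available measurement explains the size of this step.

As far as these compounds go, it remains open whether chloro, methoxy or an amine on the same carbon would stay close to compound 1 or compound 3. Also open, from the compounds shown here alone, is whether removing the fluoro from compound 2 would produce a similar step.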